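Thiazole piperidine series: ethylpyrimidine cap against tert-butoxycarbonyl

The compounds below may be only part of what the source reports. "The series", "measured", "known", "first", "only" and "open" are said of these compounds alone.

Measured compounds:
compound 1 `NC(=O)CCc1cnc(N2CCC(c3nc(COc4ccc(-n5cnnn5)cc4)cs3)CC2)nc1` — "not determined" (no result reported) in a functional assay on cells for agonist activity at Glucose-dependent insulinotropic receptor (Homo sapiens), read by a luciferase reporter, with a stated time of 6 h; on this read-out lower numbers stand for an effect already at smaller amounts and higher numbers for an effect only at larger amounts of compound
compound 2 `CC(C)(C)OC(=O)N1CCC(c2nc(COc3ccc(/C=C4\CC(=O)NC4=O)cc3)cs2)CC1` — "not determined" (no result reported) in this assay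
compound 3 `CCc1cnc(N2CCC(c3nc(COc4ccc(-n5cnnn5)cc4)cs3)CC2)nc1` — 87 nM

Compound 3 carries the only number shown; compound 1 and compound 2 have no result in this assay, so no step between measured compounds can be stated and the scatter cannot be judged from this set.

Compound 4 `CC(C)(C)OC(=O)N1CCC(c2nc(COc3ccc(-n4cnnn4)cc3)cs2)CC1` differs from compound 3 by tert-butoxycarbonyl in place of 5-ethylpyrimidin-2-yl on an amine nitrogen in a ring. For the measured compounds named here, with no comparable step available, the expectation rests on the change itself: a step beyond the scatter, towards weaker potency, is expected from compound 3 to compound 4 in this assay (a 5.7-fold higher number from compound 3 to compound 4 (0.76 log units; beyond the scatter)). Compound 4 is accordingly estimated at 500 nM, with a range from 120 nM to 3000 nM.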

Compound 4, half-maximal effective concentration: 103 nM
The estimate for compound 4 lay 4.9-fold (0.69 log units) above the measured number; measured number below the stated range.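

In this assay the change reads as a 1.2-fold higher number from compound 3 to compound 4 (0.07 log units; within the scatter) and so gives no separation between the two groups. On the amine nitrogen in a ring, a cap with no ring, tert-butoxycarbonyl, and a cap with a six-membered aromatic ring, 5-ethylpyrimidin-2-yl, stand level on this read-out. No measurement shown here explains this result.

As far as these compounds go, whether an acetyl group, a benzyl group or a plain hydrogen on this nitrogen would stay at the same level remains open. The same question applies to a carboxylic acid carried on the pyrimidine in place of the ethyl group.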